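A few compounds are considered here, and "the series" means these few. Any claim that something is new, unique, unknown or untested is made for them only; others in the source may bear on it.

Measured compounds in this study:

Compound 2, `O=C(O)Cc1sc(C(c2ccc(F)cc2)c2ccc(F)cc2)nc1-c1ccc(Cl)cc1`, gives 180 nM in an in vitro functional assay on HEK285-7 cells for antagonist activity at prostaglandin D2 receptor 2 (Homo sapiens), read by BRET and beta-arrestin recruitment; on this read-out lower numbers stand for stronger inhibition and higher numbers for weaker inhibition.
Compound 3, `O=C(O)Cc1sc(C(c2ccc(F)cc2)c2ccc(F)cc2)nc1-c1ccccc1`, gives 240 nM in this assay.
Compound 1, `Nc1nc(-c2ccc(Cl)cc2)c(CC(=O)O)s1`, reaches only > 100000 nM in this assay, which is a limit of the assay rather than a number (the limit of > 100000 nM in this assay, at which 1 of the 3 values shown sits).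

Among the two numbers, compound 3 holds the higher one, but its only neighbour is compound 2, and the step of a 1.3-fold higher number from compound 2 to compound 3 (0.12 log units; within the scatter) lies within the scatter, so the two cannot be told apart. For the measured compounds named here, that step, hydrogen in place of chloro on an aromatic carbon, is the one change at this position that has been measured.

Compound 4, `N#Cc1ccc(-c2nc(C(c3ccc(F)cc3)c3ccc(F)cc3)sc2CC(=O)O)cc1`, differs from compound 3 by cyano in place of hydrogen on an aromatic carbon. The cyano group carries one hydrogen-bond acceptor, no ring and no net charge, and sits on the six-membered carbon-only ring para to a large group; cut one bond further out, the change reads phenyl to 4-cyanophenyl.

Going by the values given here, the only step that bears on this position is the one from compound 2 to compound 3, and it stayed within the scatter. On that basis the step of a 1.1-fold lower number from compound 3 to compound 4 (0.04 log units; within the scatter) is expected to stay within the scatter as well, with no clear direction. Compound 4 is therefore estimated at 220 nM, within a range from 70 nM to 700 nM.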

Compound 4, half-maximal inhibitory concentration: 1500 nM
Estimate against measurement, compound 4: 6.8-fold (0.83 log units) below; measured number outside the range, above it.
By their numbers in this assay, from the lowest: compounds 2 and 3 (each within the scatter of the next); then compound 4. At a limit, above all of these: compound 1.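

For the compounds shown here, the position on the six-membered aromatic ring of carbon only, para to a large group, turns out not to be indifferent to what it carries: in this assay the change phenyl to 4-cyanophenyl gives a 6.3-fold higher number from compound 3 to compound 4 (0.80 log units; beyond the scatter) and so weaker inhibition, while the only earlier step here, a 1.3-fold higher number from compound 2 to compound 3 (0.12 log units; within the scatter), could not be told from scatter. Cyano in place of chloro points the same way, with an 8.3-fold higher number from compound 2 to compound 4 (0.92 log units; beyond the scatter) as the step, so on this carbon cyano is not interchangeable with either hydrogen or chloro, and the loss is modest in size. Nothing among the data shown accounts for this loss of inhibition.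

With three groups at this position, the compounds shown cannot say whether the loss is particular to cyano or would also appear with an amine, a methoxy group or a carboxylic acid on the same carbon. On these data alone, it also stays open whether cyano would give a similar step on another carbon of this ring, or with another group in place of the bis(4-fluorophenyl)methyl part of the shared core.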